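Methylating the ring amide nitrogen of compound 2

The source may report more compounds than this note shows. Statements on the series, on what has been measured and on what is new or still open speak of the compounds shown alone.

Compound 2 `COC(=O)C1=C(C)NC(=O)NC1c1cccs1` was tested in an assay on membranes from CHO cells for displacement of a labelled ligand from adenosine receptor A1 (Homo sapiens), read by scintillation counting, with a stated time of 60 min, tested at 1 uM (a higher number here means more inhibition at the concentration tested (going by the name of the read-out), a lower number less inhibition), where compound 2 gives 6%. Of the three numbers measured this is the lowest, yet the gap to compound 1 `COC(=O)C1=C(C)NC(=O)NC1c1ccoc1`, which gives 8%, lies within the scatter, so the two cannot be ordered; only compound 3 `CCCOC(=O)C1=C(C)NC(=O)NC1c1cccs1`, which gives 43%, stands clearly apart. The two measured steps are a number 2 percentage points lower from compound 1 to compound 2 (within the scatter), from thiophen-2-yl in place of furan-3-yl on a saturated ring carbon, and a number 37 percentage points higher from compound 2 to compound 3 (beyond the scatter), from ethyl in place of hydrogen on a saturated chain carbon bound to an oxygen next to a carbonyl group.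

Compound 4 `COC(=O)C1=C(C)N(C)C(=O)NC1c1cccs1` differs from compound 2 by methyl in place of hydrogen on an amide-type nitrogen in a ring. Neither measured step touches this nitrogen: one alters the aryl group on the ring carbon, the other lengthens the ester chain. For the measured compounds named here, the one large step arose solely from the ester, and compound 4 keeps the methoxycarbonyl group of compound 2 unchanged. Going by the values given here, with no step of this kind measured, the expected change for compound 4 is a number 2 percentage points higher from compound 2 to compound 4 (within the scatter), that is, none beyond the scatter. Compound 4 is therefore estimated at 8%, within a range from -5% to 25%.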

Compound 4, a percentage reported as inhibition, at one concentration (the size of the read-out at that concentration, not a potency): 30%
Compound 4: the middle estimate sits 22 percentage points below what was measured; the whole stated range lies below it.
By their numbers in this assay, from the lowest: compounds 2 and 1 (each within the scatter of the next); then compound 4; then compound 3.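

In this assay the amide-type nitrogen in the ring proves to be a position that responds: methyl in place of hydrogen there gives a number 24 percentage points higher from compound 2 to compound 4 (beyond the scatter) and leaves the methoxycarbonyl group and the thiophen-2-yl group untouched. For the compounds shown here, until now the only step beyond the scatter lay at the ester, a number 37 percentage points higher from compound 2 to compound 3 (beyond the scatter) being the change from the methyl ester to a longer chain, so the read-out now moves with a change at a second place on the shared core, and this time the added group is a single carbon. Nothing at hand accounts for the rise seen with this methyl.

The compounds shown leave open whether the rise is particular to methyl, as no ethyl, longer chain or acetyl group on this nitrogen stands among them. They also leave open whether the same methyl would add to the longer ester chain of compound 3 or would carry over to the furan-3-yl group of compound 1, since neither combination appears here.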